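Amide variation on the carbonyl carbon of the shared core

The source may report more compounds than this note shows. Statements on the series, on what has been measured and on what is new or still open speak of the compounds shown alone.

Compound 1 `Nc1c(C(=O)O)sc2nc(-c3ccccc3)cc(C(F)(F)F)c12` carries a hydroxy on the carbonyl carbon of the shared core. In an ADME assay on Huh-7 cells (Homo sapiens) for cytotoxicity, read by MTT assay, with a stated time of 72 h (a lower number here means that less compound is tolerated, a higher number that more compound is tolerated), compound 1 gives > 20000 nM, a limit of the assay. Compound 2 `Nc1c(C(=O)NC2CCCC2)sc2nc(-c3ccccc3)cc(C(F)(F)F)c12` carries cyclopentylamino at that carbonyl carbon. In this assay compound 2 gives > 20000 nM, again a limit. The step that the two limits leave unreadable from compound 1 to compound 2 cannot be read in size, as the limit of > 20000 nM in this assay, at which 2 of the 2 values shown sit, shows. Compound 3 `Nc1c(C(=O)N2CCc3sccc3C2)sc2nc(-c3ccccc3)cc(C(F)(F)F)c12` differs from compound 2 by a group of 9 heavy atoms (7 carbon, 1 nitrogen, 1 sulfur; one five-membered aromatic ring with 1 hetero atom, one six-membered non-aromatic ring with 1 hetero atom) in place of a group of 6 heavy atoms (5 carbon, 1 nitrogen; one five-membered non-aromatic ring of carbon only), on a carbonyl carbon. Going by the values given here, no measured step in this assay gives a readable size for this kind of change. Compound 3 is therefore expected to show a step of a number no higher from compound 2 to compound 3 (the limit leaves the size open) of no readable size because of the limit of > 20000 nM in this assay, at which 2 of the 2 values shown sit. The estimate for compound 3 is 20000 nM, between 10000 nM and 40000 nM.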

Compound 3, half-maximal cytotoxic concentration: > 20000 nM
Compound 3: a limit, no number (the forecaster's own chance of this, stated with the estimate: 85%); the middle value lies on the limit itself.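

In this assay compound 3 gives > 20000 nM as a limit, and its steps from compound 1 and compound 2 cannot be read in size: the limit of > 20000 nM in this assay, at which 3 of the 3 values shown sit. Where the half-maximal cytotoxic concentration of compound 1, compound 2 or compound 3 actually lies stays open.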